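Replacing a hydroxypropylamine on the shared core

The compounds below may be only part of what the source reports. "The series", "measured", "known", "first", "only" and "open" are said of these compounds alone.

Compound 1 `OCCCNc1ncnc2[nH]cc(-c3cccc(Cl)c3)c12` holds the higher of the two numbers shown: in an assay on HEK293T cells for displacement of a labelled ligand from serine/threonine-protein kinase 3 (Homo sapiens), read by NanoBRET, with a stated time of 2 h (a lower number here means a stronger inhibitor, a higher number a weaker inhibitor), compound 1 gives 668 nM, while compound 2 `CNC1CCN(c2ncnc3[nH]cc(-c4cccc(Cl)c4)c23)CC1` gives 417 nM, the step of a 1.6-fold lower number from compound 1 to compound 2 (0.20 log units; within the scatter). Compound 3 `CC(CO)CN(C)c1ncnc2[nH]cc(-c3cccc(Cl)c3)c12` differs from compound 1 by a group of 7 heavy atoms (5 carbon, 1 nitrogen, 1 oxygen; no ring) in place of a group of 5 heavy atoms (3 carbon, 1 nitrogen, 1 oxygen; no ring), on an aromatic carbon. Among the compounds with values here, only that one measured step touches the same group, and it stayed within the scatter, so the author expects compound 3 to sit near compound 1, with a step of a 1.1-fold lower number from compound 1 to compound 3 (0.05 log units; within the scatter) in this assay. Compound 3 is estimated at 600 nM, between 200 nM and 1800 nM.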

Compound 3, half-maximal inhibitory concentration: 289 nM
The estimate for compound 3 lay 2.1-fold (0.32 log units) above the measured number; low and high end bracket the measured number.
By their numbers in this assay, from the lowest: compounds 3, 2 and 1 (each within the scatter of the next, the first and the last beyond it).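

Within the data shown here, on this aromatic carbon, the open-chain group of compound 3 gives a 2.3-fold lower number from compound 1 to compound 3 (0.36 log units; beyond the scatter) in this assay, the only modest step beyond the scatter at this position so far. The step of a 1.4-fold lower number from compound 2 to compound 3 (0.16 log units; within the scatter) shows that, among these compounds, the ring of the 4-(methylamino)piperidin-1-yl group is not needed to reach this range. Nothing available explains these steps.

As far as these compounds go, it remains open whether the methyl on the nitrogen or the methyl on the chain accounts for the step from the hydroxypropylamine. From the compounds shown here alone, how a carboxylic acid or a longer chain would read here also remains open.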